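Ethoxy for 4-fluorophenyl on the isopropyl compound

The compounds below may be only part of what the source reports. "The series", "measured", "known", "first", "only" and "open" are said of these compounds alone.

Compound 1 `Cc1c(O)nc(SCC(=O)c2ccc(F)cc2)nc1Cc1cccc2ccccc12`: >= 275000 nM (a limit)
Compound 2 `CCOC(=O)CSc1nc(O)c(C)c(Cc2cccc3ccccc23)n1`: >= 287000 nM (a limit)
Compound 3 `CC(C)c1c(O)nc(SCC(=O)c2ccc(F)cc2)nc1Cc1cccc2ccccc12`: 186000 nM

Going by the values given here, in a functional assay on MT4 cells (Homo sapiens) for cytotoxicity (a lower number here means that less compound is tolerated, a higher number that more compound is tolerated), compound 3 gives 186000 nM, the only actual number so far. Compound 4 `CCOC(=O)CSc1nc(O)c(C(C)C)c(Cc2cccc3ccccc23)n1` carries ethoxy in place of 4-fluorophenyl on a carbonyl carbon. The same exchange appears as a step that the two limits leave unreadable from compound 1 to compound 2, so it offers no usable size. Isopropyl in place of methyl on an aromatic carbon, shared by both compounds of the new step, gave an at least 1.4-fold lower number from compound 1 to compound 3 (0.16 log units; that floor lies within the scatter). No step beyond the scatter is therefore expected, and the estimated step is a 1.1-fold higher number from compound 3 to compound 4 (0.05 log units; within the scatter). The estimate for compound 4 is 210000 nM, with an expected range of 110000 nM to 320000 nM.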

Compound 4, half-maximal cytotoxic concentration: 175000 nM
Beside the measured number, compound 4's estimate is 1.2-fold (0.08 log units) above it, and the stated range covers the measured number.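

In this assay, the exchange of 4-fluorophenyl for ethoxy on a carbonyl carbon becomes readable on the isopropyl compounds, as a 1.1-fold lower number from compound 3 to compound 4 (0.03 log units; within the scatter), whereas the step from compound 1 to compound 2 cannot be read. Isopropyl in place of methyl on an aromatic carbon now has a second reading, an at least 1.6-fold lower number from compound 2 to compound 4 (0.21 log units; that floor lies within the scatter). The two readings stand side by side: the same change on two cores in this assay, an at least 1.4-fold lower number (0.16 log units; that floor lies within the scatter) from compound 1 to compound 3 and an at least 1.6-fold lower number (0.21 log units; that floor lies within the scatter) from compound 2 to compound 4; the limit leaves it open whether they differ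

Going by these compounds, the true size of the isopropyl step stays open. Also open, on these data alone, is whether an amine or a carboxylic acid in place of ethoxy, or a longer chain in place of isopropyl, would give a step beyond the scatter.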